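The source may hold more compounds than are shown below. What is called first, only, known or untested is meant among the compounds shown, and "the series" means these compounds.

Measured compounds in a functional assay on MCF7 cells (Homo sapiens) for cytotoxicity, read by neutral red uptake, with a stated time of 3 days; on this read-out higher numbers stand for weaker inhibition and lower numbers for stronger inhibition:

- compound 1 `CCCCc1c(F)c(N)c2c(=O)cc(-c3ccc(N)c(F)c3)oc2c1F` — 8800 nM
- compound 2 `Nc1ccc(-c2cc(=O)c3c(N)c(F)c(C(=O)O)c(F)c3o2)cc1F` — a limit of the assay, > 10000 nM
- compound 3 `CCCCCCCCCC(=O)OCc1c(F)c(N)c2c(=O)cc(-c3ccc(N)c(F)c3)oc2c1F` — 100 nM

Of the two numbers that are not limits, compound 3 gives the lowest, and the gap from it to compound 1, which gives a higher number, lies beyond the scatter. The value of compound 2 is a limit; it is one of the values that sit at the limit of > 10000 nM in this assay, at which 1 of the 3 values shown sits.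

Compound 4 `CN(C)CCCC(=O)OCc1c(F)c(N)c2c(=O)cc(-c3ccc(N)c(F)c3)oc2c1F` differs from compound 3 in one place: dimethylamino in place of hexyl on a saturated chain carbon, three bonds along the chain from a carbonyl carbon. Among the measured compounds shown here, the only measured step, an at least 1.1-fold higher number from compound 1 to compound 2 (0.05 log units; that floor lies within the scatter), concerns the group on the shared core and not the ester chain, so no measured step covers this kind of change directly. For the measured compounds named here, the butyl of compound 1 and the longer ester tail of compound 3 give widely separated numbers, but a shortened tail carrying dimethylamino has no measured counterpart here.

Compound 4 is therefore expected to give a higher number than compound 3 in this assay, a step of an 8.0-fold higher number from compound 3 to compound 4 (0.90 log units; beyond the scatter) being the estimate. The estimate for compound 4 is 800 nM, expected to lie between 150 nM and 5000 nM.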

Compound 4, half-maximal inhibitory concentration: 29 nM
Compound 4: middle estimate off by 28-fold (1.44 log units), on the high side, and the stated range ends above it.
By their numbers in this assay, from the lowest: compound 4; then compound 3; then compound 1. At a limit, above all of these: compound 2.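

In this assay, putting dimethylamino in place of hexyl on a saturated chain carbon, three bonds along the chain from a carbonyl carbon, shows that the ester tail need not be a long, all-carbon chain to give a low number; the number in fact falls further (a 3.4-fold lower number from compound 3 to compound 4 (0.54 log units; beyond the scatter)). Compound 4 also stands far from the compounds without an ester tail, both the butyl compound (a 300-fold lower number from compound 1 to compound 4 (2.48 log units; beyond the scatter)) and the carboxy compound (an at least 340-fold lower number from compound 2 to compound 4 (2.53 log units; beyond the scatter)). The value of compound 2 is a limit of the assay, so that second step is only a floor: the limit of > 10000 nM in this assay, at which 1 of the 4 values shown sits.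

The compounds shown do not separate the effect of the dimethylamino group from that of the shorter chain. Also open, going by these compounds, is how a tail of the same length ending in a primary amine or a carboxylic acid would compare, or a longer chain carrying dimethylamino.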